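This account rests on a few compounds, and the source may have more. Where it says the series, first, only, none or still open, it means among the compounds named here.

Compound 1 `Fc1ccc(-c2csc(N/N=C/c3ccc(-n4cncn4)cc3)n2)cc1` gives 35.9% in an ADME assay on THP-1 cells (Homo sapiens) for cytotoxicity, read by MTT assay, tested at 50 ug/mL; on this read-out higher numbers stand for more inhibition at the one concentration tested (going by the name of the read-out) and lower numbers for less inhibition. Compound 2 `Clc1ccc(-c2csc(N/N=C/c3ccc(-n4cncn4)cc3)n2)cc1` gives 28.4%. Compound 3 `Clc1ccc(-c2csc(N/N=C/c3ccc(-n4cncn4)cc3)n2)c(Cl)c1` gives 8.9%.

Compound 3 stands lowest of the three in this assay: compound 2 lies nearest, and compound 1 furthest, with both gaps beyond the scatter. The unmeasured compound 4 `Cc1ccc(-c2csc(N/N=C/c3ccc(-n4cncn4)cc3)n2)cc1` differs from compound 3 only at the aryl group on the shared core: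

4-methylphenyl in place of 2,4-dichlorophenyl on an aromatic carbon

For the measured compounds named here, two measured steps bear on this change. Replacing 4-fluorophenyl by 2,4-dichlorophenyl gave a number 27 percentage points lower from compound 1 to compound 3 (beyond the scatter), and adding a second chloro gave a number 19.5 percentage points lower from compound 2 to compound 3 (beyond the scatter). Compound 4 moves back to a phenyl with a single small group in the same position as in compounds 1 and 2, and the step from compound 1 to compound 2 was within the scatter, so a return toward their level is expected. An upward step of about a number 21.1 percentage points higher from compound 3 to compound 4 (beyond the scatter) is therefore expected in this assay. Compound 4 is estimated at 30%, likely between 15% and 45%.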

Compound 4, a percentage reported as inhibition, at one concentration (the size of the read-out at that concentration, not a potency): 13.6%
Estimate against measurement, compound 4: 16.4 percentage points above; measured number outside the range, below it.
By their numbers in this assay, from the lowest: compounds 3 and 4 (each within the scatter of the next); then compounds 2 and 1 (each within the scatter of the next).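

In this assay the change to 4-methylphenyl from 2,4-dichlorophenyl gave a number 4.7 percentage points higher from compound 3 to compound 4 (within the scatter) and so did not undo the drop seen with the second chloro. A single group on the phenyl is therefore not enough to hold the level of compounds 1 and 2: methyl in place of chloro gave a number 14.8 percentage points lower from compound 2 to compound 4 (beyond the scatter) and methyl in place of fluoro gave a number 22.3 percentage points lower from compound 1 to compound 4 (beyond the scatter) even though fluoro and chloro lay within the scatter of each other. No measurement shown offers an explanation for this difference between methyl and the two halogens.

On these data alone, it remains open whether an unsubstituted phenyl or a 4-methoxyphenyl would fall with compounds 1 and 2 or with compounds 3 and 4. Also open, as far as these compounds go, is how a phenyl carrying an amine or a carboxylic acid would read here.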